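A few compounds are considered here, and "the series" means these few. Any claim that something is new, unique, unknown or untested is made for them only; others in the source may bear on it.

Compound 1 `Cc1occc1-c1nnc2sc(-c3cc(O)nc(O)c3)nn12`: 16.5%
Compound 2 `COc1ccc(Cl)c(-c2nnc3sc(-c4ccnc(Cl)c4)nn23)c1`: 23.5%

In a functional assay on the whole organism (strain Wistar Albino) for inhibition, with Rattus norvegicus as the target, read by paw edema, with a stated time of 3 h, at a dose of 20 mg/kg (a higher number here means more inhibition at the dose given (going by the name of the read-out), a lower number less inhibition), compound 2 gives 23.5% and compound 1 gives 16.5%; the two lie within the usual scatter of each other, so neither is set apart. Compound 3 `COc1ccc(Cl)c(-c2nnc3sc(-c4ccnc(F)c4)nn23)c1` differs from compound 2 in one place: fluoro in place of chloro on an aromatic carbon. Among the compounds with values here, no step between measured compounds is available to judge such a swap. The change is small, and the expected step of a number 1.5 percentage points lower from compound 2 to compound 3 (within the scatter) is within the scatter, without a clear direction. Compound 3 is therefore estimated at 22%, with a range from 11% to 33%.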

Compound 3, a percentage reported as inhibition, in the whole organism at one dose (the size of the read-out at that dose, not a potency): 25.9%
Compound 3: middle estimate off by 3.9 percentage points, on the low side, and the stated range covers the measured number.
By their numbers in this assay, from the lowest: compounds 1, 2 and 3 (each within the scatter of the next).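

The step in this assay on this position, on an aromatic carbon next to the ring nitrogen, is a number 2.4 percentage points higher from compound 2 to compound 3 (within the scatter), so fluoro in place of chloro leaves the two compounds unseparated at this dose. Within the data shown here, this is the first direct reading of a change at this position, as compound 1 differs from compound 2 in more than one place. Nothing shown here offers an explanation for this result.

As far as these compounds go, it remains open whether an amine, a methoxy group or a nitrile at this position would read apart from the two halogens. From the compounds shown here alone, it is also open whether compound 2 and compound 3 would separate at other doses or times.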